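This account rests on a few compounds, and the source may have more. Where it says the series, first, only, none or still open, it means among the compounds named here.

Measured compounds: compound 1 `COc1ccc2c(c1)c(-c1cc(C(F)(F)F)ccn1)cn2S(=O)(=O)c1ccc(C)cc1` at > 100000 nM; compound 2 `Cc1ccc(S(=O)(=O)n2cc(-c3cc(C(F)(F)F)cc(-c4cn(S(=O)(=O)c5ccc(C)cc5)c5cc(Br)ccc45)n3)c3ccc(Br)cc32)cc1` at > 100000 nM.

In a functional assay on P388 cells (Mus musculus) for cytotoxicity (on this read-out higher numbers stand for weaker inhibition and lower numbers for stronger inhibition), compound 1 gives > 100000 nM, which is a limit of the assay and not a number. In this assay compound 2 gives > 100000 nM, likewise a limit. Going by the values given here, both values sit at the limit of > 100000 nM in this assay, at which 2 of the 2 values shown sit, so no step between measured compounds can be stated. Compound 3 `Cc1ccc(S(=O)(=O)n2cc(-c3cc(C(F)(F)F)ccn3)c3cc(OCc4ccccc4)ccc32)cc1` differs from compound 1 by phenyl in place of hydrogen on a saturated chain carbon bound to an oxygen on an aromatic ring. With both measured values at the limit, no step beyond the scatter is expected in either direction. Compound 3 is expected at 150000 nM (range 30000 nM to 1000000 nM), most likely again reported only as a limit. This means an expected step that the limit leaves unreadable from compound 1 to compound 3.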

Compound 3, half-maximal inhibitory concentration: > 100000 nM
Compound 3: no number, only a limit; the forecaster's own chance of this, stated with the estimate: 80%; the middle value does not contradict the limit.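

In this assay compound 3 gives > 100000 nM, a limit of the assay and not a number. No step from compound 1 to compound 3 can be read: the limit of > 100000 nM in this assay, at which 3 of the 3 values shown sit.

The compounds shown leave open which change to the shared core, if any, would give a measurable value in this assay.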